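Acyl replacement of butyl on the ring nitrogen

The source may report more compounds than this note shows. Statements on the series, on what has been measured and on what is new or still open speak of the compounds shown alone.

Measured so far in an assay on HEK293 cells for positive allosteric modulation of metabotropic glutamate receptor 5 (Homo sapiens), read by FLIPR, with a stated time of 1 h; on this read-out lower numbers stand for an effect already at smaller amounts and higher numbers for an effect only at larger amounts of compound:
- compound 1 `O=C1NCCc2nc(C#Cc3ccccc3)sc21`: 112 nM
- compound 2 `O=C1c2sc(C#Cc3ccccc3)nc2CN1C1CC1`: reported only as a limit, > 10000 nM
- compound 3 `CCCCN1CCc2nc(C#Cc3ccccc3)sc2C1`: 110 nM

Compound 3 carries the lowest number of the two that are numbers; compound 1 sits next to it, and the two values lie within the scatter of each other, so no order between them is claimed. For compound 2 the assay gave a limit and no number (the limit of > 10000 nM in this assay, at which 1 of the 3 values shown sits).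

Compound 4 `O=C(C1CC12CCC2)N1CCc2nc(C#Cc3ccccc3)sc2C1` differs from compound 3 in one place a group of 8 heavy atoms (7 carbon, 1 oxygen; one three-membered non-aromatic ring of carbon only, one four-membered non-aromatic ring of carbon only) in place of a group of 4 heavy atoms (4 carbon; no ring), on an amine nitrogen in a ring. Going by the values given here, no pair of measured compounds shows this kind of change, so the size of the step is not read from the series. Compound 1, which holds a carbonyl on the shared core and gives 112 nM, offers the only pointer that a carbonyl near this nitrogen is tolerated. For compound 4 the expectation is a step of a 2.0-fold higher number from compound 3 to compound 4 (0.30 log units; within the scatter) that stays close to the scatter, leaning toward a somewhat higher number. Compound 4 is estimated at 220 nM, within a range from 45 nM to 1500 nM.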

Compound 4, half-maximal effective concentration: 3.9 nM
For compound 4 the middle estimate is 56-fold (1.75 log units) above the measured one, outside the stated range (below it).
By their numbers in this assay, from the lowest: compound 4; then compounds 3 and 1 (each within the scatter of the next). At a limit, above all of these: compound 2.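

In this assay, the group with a three-membered and a four-membered non-aromatic ring of carbon only, which brings a carbonyl onto the amine nitrogen in a ring, replaces butyl and gives a 28-fold lower number from compound 3 to compound 4 (1.45 log units; beyond the scatter). Going by these compounds alone, this is the first step that can be read at this position, and it shows that the number responds strongly to the group on this nitrogen, well beyond the scatter. Nothing measured in the compounds shown gives a reason for the size of this step.

From the compounds shown here alone, how an acetyl or a cyclopropylcarbonyl group on this nitrogen would compare remains open, so the shares of the carbonyl and of the two carbon rings in the step cannot be separated. Going by these compounds, whether a sulfonyl or a urea linkage in place of the carbonyl would hold the low number of compound 4 is equally open.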